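The source may report more compounds than this note shows. Statements on the series, on what has been measured and on what is new or still open speak of the compounds shown alone.

Three compounds have been measured in a functional assay on HCT-116 cells (Homo sapiens) for antiproliferative activity, read by MTT assay, with a stated time of 48 h; on this read-out lower numbers stand for stronger inhibition and higher numbers for weaker inhibition:

Compound 1 `COc1cc(/C=C/C(C)=O)ccc1OCc1cn(-c2c(F)cccc2F)nn1`: 37700 nM
Compound 2 `COc1cc(/C=C/C(C)=O)ccc1OCc1cn(-c2ccccc2CO)nn1`: > 100000 nM, a limit
Compound 3 `COc1cc(/C=C/C(C)=O)ccc1OCc1cn(-c2ccc(/N=N/c3ccccc3)cc2)nn1`: > 100000 nM, a limit

Compound 3 has no number, and its reading is the limit of > 100000 nM in this assay, at which 2 of the 3 values shown sit. Compound 4 `COc1ccc(-n2cc(COc3ccc(/C=C/C(C)=O)cc3OC)nn2)cc1` differs from compound 3 in one place, where methoxy replaces the larger group: a group of 2 heavy atoms (1 carbon, 1 oxygen; no ring) in place of a group of 8 heavy atoms (6 carbon, 2 nitrogen; one six-membered aromatic ring of carbon only), on an aromatic carbon.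

Going by the values given here, only one measured step bears on this change, as it also alters the group on the aromatic nitrogen: an at least 2.6-fold higher number from compound 1 to compound 2 (0.42 log units; beyond the scatter). That step is at least modest and has only a lower bound on its size. Among the compounds with values here, compound 1 at 37700 nM is the only number. For compound 4 a modest move towards lower numbers is expected at best, and a reading that stays at the limit is quite possible. The expected change is an at least 1.4-fold lower number from compound 3 to compound 4 (0.15 log units; that floor lies within the scatter). Compound 4 is estimated at 70000 nM, with an expected range from 30000 nM to 100000 nM.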

Compound 4, half-maximal inhibitory concentration: 21300 nM
For compound 4 the middle estimate is 3.3-fold (0.52 log units) above the measured one; measured number outside the range, below it.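

Going by these compounds alone, with methoxy in place of the larger group on this aromatic carbon, para to a large group, the reading in this assay comes down from the limit, with an at least 4.6-fold lower number from compound 3 to compound 4 (0.67 log units; beyond the scatter); this is the first number for a group in that place. Against the 2,6-difluorophenyl group the change to 4-methoxyphenyl gives a 1.8-fold lower number from compound 1 to compound 4 (0.25 log units; within the scatter), which lies within the scatter, so these two groups do not separate here. The change from 2-(hydroxymethyl)phenyl gives an at least 4.6-fold lower number from compound 2 to compound 4 (0.67 log units; beyond the scatter), and this step, like the one from compound 3, is only a floor, as each starts from a limit: the limit of > 100000 nM in this assay, at which 2 of the 4 values shown sit.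

Going by these compounds, whether a hydroxyl, an amine or a carboxylic acid on this aromatic carbon would read like methoxy stays open. So does whether a longer chain such as ethoxy would hold the reading or lose it.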